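This account rests on a few compounds, and the source may have more. Where it says the series, first, only, none or still open, it means among the compounds named here.

Compound 1 `CC(C)(C)C#Cc1cn([C@H]2C[C@H](O)[C@@H](CO)O2)c(=O)[nH]c1=O` is a modified nucleoside whose core carries a 3,3-dimethylbut-1-yn-1-yl group. In a functional assay on L1210 cells (Mus musculus) (on this read-out higher numbers stand for weaker inhibition and lower numbers for stronger inhibition), compound 1 gives 287 ug/mL, a weak inhibition and the only plain number measured among the compounds shown. A second compound, compound 2 `Cc1ccc(S(=O)(=O)OCCC#Cc2cn([C@H]3C[C@H](O)[C@@H](CO)O3)c(=O)[nH]c2=O)cc1`, gives > 200 ug/mL in this assay, which is a limit of the assay rather than a number. That limit is recorded as the limit of > 200 ug/mL in this assay, at which 1 of the 2 values shown sits.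

Compound 3 `CCCCC#Cc1cn([C@H]2C[C@H](O)[C@@H](CO)O2)c(=O)[nH]c1=O` has the same atoms as compound 1, joined differently: butyl in place of tert-butyl on a triple-bonded carbon. Within the data shown here, no measured pair shows what such a swap does in this assay, so the expected step is modest and in no firm direction. Compound 3 is expected to give about 200 ug/mL in this assay, with a range from 60 ug/mL to 600 ug/mL. The expected step of a 1.4-fold lower number from compound 1 to compound 3 (0.16 log units; within the scatter) stays close to the scatter of repeated measurements.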

Compound 3, concentration for 50% inhibition: 1000 ug/mL
For compound 3 the middle estimate is 5.0-fold (0.70 log units) below the measured one, outside the stated range (above it).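

In this assay, the way the four carbons of the group on the triple-bonded carbon are joined is enough on its own to change the read-out: replacing tert-butyl with butyl gives a 3.5-fold higher number from compound 1 to compound 3 (0.54 log units; beyond the scatter). Since a higher number stands for weaker inhibition, butyl is the weaker of the two groups in this one pair, even though neither the atoms nor their number differ. Among these compounds, this is the first readable step at this position, so it shows that the position responds to a change in the joining of the carbons, but a single pair sets no trend.

Compound 2 is represented only by a limit, and steps to it cannot be read: the limit of > 200 ug/mL in this assay, at which 1 of the 3 values shown sits. Going by these compounds, whether a shorter chain, a longer chain or a chain ending in an amine would give stronger inhibition remains open.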